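A Second Chloro Group on a Weak Inhibitor

The source may hold more compounds than are shown below. What is called first, only, known or untested is meant among the compounds shown, and "the series" means these compounds.

Compound 1 `CC1(C)N=C(N)N=C(N)N1Cc1ccccc1`: 19500 nM
Compound 2 `CC1(C)N=C(N)N=C(N)N1Cc1ccc(Cl)cc1`: 29900 nM
Compound 3 `Cc1nc(N)nc(Nc2cccc(Cl)c2)n1`: > 100000 nM

In an assay for inhibition of Dihydrofolate reductase (Bos taurus), using NADPH (on this read-out lower numbers stand for stronger inhibition and higher numbers for weaker inhibition), compound 1 gives 19500 nM and compound 2 gives 29900 nM. The change between them, (chloro in place of hydrogen on an aromatic carbon), made a 1.5-fold higher number from compound 1 to compound 2 (0.19 log units; within the scatter). For compound 3 the assay reports only a limit, > 100000 nM (the limit of > 100000 nM in this assay, at which 1 of the 3 values shown sits). How the core of compound 3 differs from the core of compound 1 is not broken down here.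

Compound 4 `Cc1nc(N)nc(Nc2ccc(Cl)c(Cl)c2)n1` is not yet measured. It carries the same kind of change as compound 2, (chloro in place of hydrogen on an aromatic carbon), though here the place is ortho to a chloro group and para to a group of 9 heavy atoms, whereas in compound 2 it is para to a large group. Because the earlier step was a 1.5-fold higher number from compound 1 to compound 2 (0.19 log units; within the scatter), the step for compound 4 is expected to be small, a step that the limit leaves unreadable from compound 3 to compound 4. Compound 4 is therefore estimated at 150000 nM in this assay, most likely again only a limit.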

Compound 4, half-maximal inhibitory concentration: > 100000 nM
Compound 4 ended at the assay's limit (the forecaster's own chance of this, stated with the estimate: 80%); the middle value lies beyond the limit too.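

Compound 3 and compound 4 are both reported only as limits, so no step between them can be read: the limit of > 100000 nM in this assay, at which 2 of the 4 values shown sit.

The compounds shown leave open whether the added chloro group changes inhibition at all.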